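This account rests on a few compounds, and the source may have more. Where it says the series, first, only, none or still open, it means among the compounds named here.

Compound 3 `O=C(C1CC1)N1CCN(Cc2nc3ccccc3n2Cc2ccc(C(F)(F)F)cc2)CC1` gives 37% in an assay on isolated protein for inhibition of aldehyde dehydrogenase 1A1 (Homo sapiens), read by spectrophotometry, tested at 10 uM (a higher number here means more inhibition at the concentration tested (going by the name of the read-out), a lower number less inhibition), and sits second of the three measured numbers: compound 1 `CC(C)Cn1c(CN2CCN(C(=O)C3CC3)CC2)nc2ccccc21` gives 13.1%, with the step of a number 23.9 percentage points higher from compound 1 to compound 3 (beyond the scatter), and compound 2 `CC(C)CCn1c(CN2CCN(C(=O)C3CC3)CC2)nc2ccccc21` gives 70%, with the step of a number 33 percentage points lower from compound 2 to compound 3 (beyond the scatter). Compound 4 `O=C(C1CC1)N1CCN(Cc2nc3ccccc3n2Cc2ccc(Cl)cc2)CC1` differs from compound 3 by chloro in place of trifluoromethyl on an aromatic carbon. Among the measured compounds shown here, no measured step touches this ring substituent; all three steps, including a number 56.9 percentage points higher from compound 1 to compound 2 (beyond the scatter), change the group on the saturated chain carbon bound to the aromatic nitrogen, so they give no direction for this step. With nothing bearing on it, the expected step of a number 1 percentage points higher from compound 3 to compound 4 (within the scatter) is set to none beyond the scatter. Compound 4 is therefore estimated at 38%, in the range 18% to 60%.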

Compound 4, a percentage reported as inhibition, at one concentration (the size of the read-out at that concentration, not a potency): 56.6%
For compound 4 the middle estimate is 18.6 percentage points below the measured one; the measured number falls inside the stated range.
By their numbers in this assay, from the lowest: compound 1; then compound 3; then compound 4; then compound 2.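

In this assay the substituent on this aromatic carbon matters: chloro in place of trifluoromethyl gives a number 19.6 percentage points higher from compound 3 to compound 4 (beyond the scatter) and is the only step shown at this position. The 4-chlorophenyl group gives a number 43.5 percentage points higher from compound 1 to compound 4 (beyond the scatter) against isopropyl, yet a number 13.4 percentage points lower from compound 2 to compound 4 (beyond the scatter) against isobutyl, so compound 2 stays highest of the four. No measured evidence accounts for the step from trifluoromethyl to chloro.

As far as these compounds go, whether bromo or methoxy on the same carbon would match chloro remains open. So does whether the chloro step would hold with isobutyl on the chain carbon.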